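Swapping the pyrazole on the benzyl arm of compound 1

The source may report more compounds than this note shows. Statements on the series, on what has been measured and on what is new or still open speak of the compounds shown alone.

Measured so far:
- compound 1, `CSc1cc(C)nc(SC)c1NC(=O)N(Cc1ccccc1)Cc1cccc(-c2cc[nH]n2)c1`: 0.046 mg/kg
- compound 2, `COc1ccc(CN(Cc2cccc(-c3cc[nH]n3)c2)C(=O)Nc2c(SC)cc(C)nc2SC)cc1`: < 0.1 mg/kg

Among the measured compounds shown here, in a functional assay on a cell-free system (plasma) with sterol O-acyltransferase, Soat (Rattus norvegicus) as the target (a lower number here means that less compound is needed, a higher number that more compound is needed for the effect), compound 1 gives 0.046 mg/kg, the only number in the set. Compound 2, which carries a methoxy in place of hydrogen on an aromatic carbon of the benzyl group, shows in this assay only a limit, < 0.1 mg/kg. For the measured compounds named here, the one measured step, a step that the limit leaves unreadable from compound 1 to compound 2, is therefore unreadable, as the limit of < 0.1 mg/kg in this assay, at which 1 of the 2 values shown sits, hides its size. Compound 1 thus stands alone as the single fixed point.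

Compound 3, `CSc1cc(C)nc(SC)c1NC(=O)N(Cc1ccccc1)Cc1cccc(-c2cnn(C)c2)c1`, differs from compound 1 at the other benzyl arm: 1-methyl-1H-pyrazol-4-yl in place of 1H-pyrazol-3-yl on an aromatic carbon. Going by the values given here, no measured step touches the pyrazole, so nothing in the data sets the size or direction of this change in this assay. Only the closeness of compound 2, whose limit sits in the same low range as compound 1, suggests the core tolerates changes on the benzyl groups. A step of roughly the usual scatter is expected, a 1.7-fold higher number from compound 1 to compound 3 (0.24 log units; within the scatter), with no firm direction. Compound 3 is thus estimated at 0.08 mg/kg, in the range 0.025 mg/kg to 0.3 mg/kg.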

Compound 3, dose for half-maximal effect: > 0.1 mg/kg
Compound 3: a limit, no number; the forecaster's own chance of this, stated with the estimate: 20%; middle value at least 1.2-fold (0.09 log units) from the limit.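

In this assay, the pyrazole arm proves sensitive to change, which compound 2 could not show: its change lies on the other benzyl group, and the step to it cannot be read. Placing 1-methyl-1H-pyrazol-4-yl in place of 1H-pyrazol-3-yl gives an at least 2.1-fold higher number from compound 1 to compound 3 (0.33 log units; beyond the scatter), the first readable step in the set and one that lies beyond the scatter, and with it the count of hydrogen-bond donors on this group goes from 1 to 0. Compound 3 shows a limit and not a number, so the step has a lower bound but no full size: the limit of > 0.1 mg/kg in this assay, at which 1 of the 3 values shown sits.

The change alters the ring's point of attachment and adds a methyl group in one move, so the compounds shown do not separate the two. Going by these compounds, it remains open how 1H-pyrazol-4-yl or 1-methyl-1H-pyrazol-3-yl would read at this position on the shared core, and whether an imidazole or a carboxylic acid in the same place would stay close to compound 1.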